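The source may report more compounds than this note shows. Statements on the series, on what has been measured and on what is new or still open speak of the compounds shown alone.

In a physicochemical assay for lipophilicity, measured as octanol-water partition, at pH 7.4 (on this read-out lower numbers stand for lower lipophilicity and higher numbers for higher lipophilicity), compound 1 `CN1CCN(c2ccc(Cn3c(=O)[nH]c4c(N)nc(C(F)(F)F)cc43)cn2)CC1` gives 1.8 and compound 2 `Nc1ccc(Cn2c(=O)[nH]c3c(N)nc(C(F)(F)F)cc32)cn1` gives 1.5, so these two numbers stand within the usual scatter of each other. Compound 3 `Nc1nc(C(F)(F)F)cc2c1[nH]c(=O)n2Cc1ccc(NCC2CC2)nc1` has cyclopropylmethyl in place of hydrogen on a nitrogen on an aromatic ring of compound 2: cyclopropylmethyl in place of hydrogen on a nitrogen on an aromatic ring. Among the compounds with values here, only one measured step bears on this, amino in place of 4-methylpiperazin-1-yl, and it is a number 0.30 log units lower from compound 1 to compound 2 (within the scatter). Within the data shown here, it is a loose guide, as no measured compound has this exact change, but a moderate rise beyond the scatter is expected. For compound 3, the expected step in this assay is a number 0.80 log units higher from compound 2 to compound 3 (beyond the scatter). Compound 3 is estimated at 2.3, within a range from 1.8 to 2.8.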

Compound 3, distribution coefficient: 3.2
Beside the measured number, compound 3's estimate is 0.90 log units below it; measured number outside the range, above it.
By their numbers in this assay, from the lowest: compounds 2 and 1 (each within the scatter of the next); then compound 3.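

In this assay the nitrogen on an aromatic ring proves to be a place where one change can move the number well beyond the scatter: cyclopropylmethyl in place of hydrogen gives a number 1.70 log units higher from compound 2 to compound 3 (beyond the scatter), whereas the earlier step stayed within the scatter. Replacing the whole 4-methylpiperazin-1-yl with (cyclopropylmethyl)amino also gives a large step, a number 1.40 log units higher from compound 1 to compound 3 (beyond the scatter), on the same aromatic carbon. Nothing measured here explains the size of these steps. Going by these compounds, whether a longer chain or a carboxylic acid on that nitrogen would shift the number as far remains open. A single added group shows no trend.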